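This account rests on a few compounds, and the source may have more. Where it says the series, first, only, none or still open, it means among the compounds named here.

Compounds measured so far in an ADME assay on microsomes from liver (Homo sapiens) for metabolic stability, read by LC-MS, with a stated time of 10 min; on this read-out higher numbers stand for a more stable compound and lower numbers for a less stable compound:
Compound 1 `c1cnc2c(c1)CCC[C@@H]2N(CC1CC1)C[C@H]1Cc2c(cccc2N2CCNCC2)CN1` gives 82.1%
Compound 2 `CC(C)N(C[C@H]1Cc2c(cccc2N2CCNCC2)CN1)[C@H]1CCCc2cccnc21` gives 75%
Compound 3 `CCCN(C[C@H]1Cc2c(cccc2N2CCNCC2)CN1)[C@H]1CCCc2cccnc21` gives 100%

Compound 3 holds the highest of these numbers (100%), and both other compounds lie beyond the scatter from it. The next compound, compound 4 `c1cnc2c(c1)CCC[C@@H]2N(CC1CCCCC1)C[C@H]1Cc2c(cccc2N2CCNCC2)CN1`, has not yet been measured. The structural change from compound 3 (cyclohexyl in place of ethyl on a saturated chain carbon bound to an amine nitrogen) can also be read, cut one bond further out, as propyl to cyclohexylmethyl.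

Going by the values given here, three measured steps bear on this change. The closest one also brings a ring into this place, and it runs the other way: a number 17.9 percentage points higher from compound 1 to compound 3 (beyond the scatter) as ethyl replaces cyclopropyl. A second step, a number 25 percentage points higher from compound 2 to compound 3 (beyond the scatter) with propyl in place of isopropyl, is also modest. The third, a number 7.1 percentage points lower from compound 1 to compound 2 (within the scatter) is within the scatter. So in these three compounds, both side chains other than propyl go with a lower number, and none goes against this. Among the compounds with values here, no measured compound carries a six-membered ring here, so the size of the drop is uncertain.

A modest downward step beyond the scatter is expected, estimated as a number 28 percentage points lower from compound 3 to compound 4 (beyond the scatter) for now. In this assay compound 4 is estimated at 72% with an expected range from 48% to 94% (an estimate, not a measurement).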

Compound 4, percent of the compound remaining: 81.6%
Compound 4: the middle estimate sits 9.6 percentage points below what was measured; low and high end bracket the measured number.
By their numbers in this assay, from the lowest: compounds 2, 4 and 1 (each within the scatter of the next); then compound 3.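

In this assay, placing a cyclohexyl ring on a saturated chain carbon bound to an amine nitrogen, instead of the open ethyl, gives a number 18.4 percentage points lower from compound 3 to compound 4 (beyond the scatter) and so extends the earlier picture to a much larger ring. Ring size itself makes no readable difference here, since exchanging cyclopropyl for cyclohexyl gives a number 0.5 percentage points lower from compound 1 to compound 4 (within the scatter) and the two compounds cannot be told apart. The branched side chain also falls into the same group, as cyclohexylmethyl in place of isopropyl gives a number 6.6 percentage points higher from compound 2 to compound 4 (within the scatter) and leaves these compounds within the scatter, so among the four compounds shown only the propyl chain of compound 3 stands apart, with no compound going against this.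

Still open, on these data alone, is whether this standing belongs to unbranched chains in general or to propyl alone, which a butyl chain or a ring holding an oxygen atom at this place could help to test. Nothing available explains why the propyl compound differs from the other three.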